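The Same Sulfur-Side Swap Carried to a Second Core

The source may hold more compounds than are shown below. What is called first, only, known or untested is meant among the compounds shown, and "the series" means these compounds.

Measured in a functional assay on DU-145 cells (Homo sapiens) for inhibition, read by trypan blue exclusion, with a stated time of 96 h; a lower number here means a stronger inhibitor of growth, a higher number a weaker inhibitor of growth:
compound 1 `O=C(/C(=C\c1c[nH]c2ccc(Br)cc12)SCc1ccc(Cl)cc1Cl)c1ccc(Cl)cc1` gives 10000 nM;
compound 2 `O=C(/C(=C\c1c[nH]c2ccc(Br)cc12)SCc1ccc(F)cc1)c1ccc(Cl)cc1` gives 50000 nM;
compound 3 `CN(C)c1ccc(/C=C(/SCc2ccc(Cl)cc2Cl)C(=O)c2ccc(Cl)cc2)cc1` gives 50000 nM.

Compound 4 `CN(C)c1ccc(/C=C(/SCc2ccc(F)cc2)C(=O)c2ccc(Cl)cc2)cc1` has not yet been measured in this assay. It differs from compound 3 by 4-fluorophenyl in place of 2,4-dichlorophenyl on a saturated chain carbon bound to a sulfur. The same change, at the same place, separates compound 1 from compound 2, where it gave a 5.0-fold higher number from compound 1 to compound 2 (0.70 log units; beyond the scatter). The two cores differ by 4-(dimethylamino)phenyl in place of 5-bromo-1H-indol-3-yl on a double-bonded chain carbon bound to a double-bonded chain carbon; with the 2,4-dichlorobenzyl group in place, that difference gave a 5.0-fold higher number from compound 1 to compound 3 (0.70 log units; beyond the scatter). Compound 2 and compound 3 stand level with each other in this assay, so no order between them can be read.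

Since the change gave a 5.0-fold higher number from compound 1 to compound 2 (0.70 log units; beyond the scatter) on the core of compound 1, a step of similar size is expected on the core of compound 3, a 3.0-fold higher number from compound 3 to compound 4 (0.48 log units; beyond the scatter), although the number for compound 3 already lies at the high end of what this assay has returned here, so a limit rather than a number is a real possibility. Compound 4 is therefore estimated at 150000 nM in this assay, with a likely range from 50000 nM to 500000 nM.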

Compound 4, concentration for 50% growth inhibition: 50000 nM
Estimate against measurement, compound 4: 3.0-fold (0.48 log units) above, and the stated range covers the measured number.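

In this assay, among these compounds, 4-fluorophenyl in place of 2,4-dichlorophenyl gave no change at the digits printed from compound 3 to compound 4 (within the scatter), so the step seen on the core of compound 1 did not carry over to the second core: the same change on two cores in this assay, a 5.0-fold higher number (0.70 log units; beyond the scatter) from compound 1 to compound 2 and no change at the digits printed (within the scatter) from compound 3 to compound 4, 5.0-fold (0.70 log units) apart, beyond the scatter of two such steps Read the other way, the change of core with the 4-fluorobenzyl group in place gave no change at the digits printed from compound 2 to compound 4 (within the scatter), which also departs from the step seen with the 2,4-dichlorobenzyl group: the same change on two cores in this assay, a 5.0-fold higher number (0.70 log units; beyond the scatter) from compound 1 to compound 3 and no change at the digits printed (within the scatter) from compound 2 to compound 4, 5.0-fold (0.70 log units) apart, beyond the scatter of two such steps The two changes therefore do not act independently across these four compounds, but the whole difference rests on compound 1, the only one whose number differs from the other three, and the data do not show why.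

As far as these compounds go, it remains open how a plain benzyl group or a monochlorobenzyl group on the sulfur would behave on either core. Also open, from the compounds shown here alone, is whether a third core, such as one carrying a methoxy group in place of the dimethylamino group, would follow compound 1 or compound 3.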